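The source may hold more compounds than are shown below. What is called first, only, known or untested is meant among the compounds shown, and "the series" means these compounds.

Working notes on the series. Compound 1 `FC(F)(F)c1ccc(/C=C\c2cc3ccccc3nc2Cl)cc1` gives 4220 nM in a functional assay on HeLa cells (Homo sapiens) for antiproliferative activity, read by sulforhodamine B assay, with a stated time of 72 h; on this read-out higher numbers stand for weaker inhibition and lower numbers for stronger inhibition. Compound 2 `COc1ccc2nc(Cl)c(/C=C\c3ccc(C(F)(F)F)cc3)cc2c1` carries methoxy in place of hydrogen on an aromatic carbon relative to the core of compound 1; in this assay compound 2 gives 16200 nM, and the step is a 3.8-fold higher number from compound 1 to compound 2 (0.58 log units; beyond the scatter). Compound 3 `FC(F)(F)c1cccc(/C=C\c2cc3ccccc3nc2Cl)c1` has the same atoms as compound 1 joined differently; the difference between the two cores is not broken down here. In this assay compound 3 gives 2850 nM, a value within the scatter of that of compound 1, while the value of compound 2 stands clearly higher. Compound 4 `COc1ccc2nc(Cl)c(/C=C\c3cccc(C(F)(F)F)c3)cc2c1` differs from compound 3 by methoxy in place of hydrogen on an aromatic carbon, the same change as that from compound 1 to compound 2. Because a 3.8-fold higher number from compound 1 to compound 2 (0.58 log units; beyond the scatter) gave a higher number, a step of like size is expected here, a 3.7-fold higher number from compound 3 to compound 4 (0.57 log units; beyond the scatter). Compound 4 is therefore estimated at 10500 nM, with a likely range of 4500 nM to 25000 nM.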

Compound 4, half-maximal inhibitory concentration: 3030 nM
Compound 4: the middle estimate sits 3.5-fold (0.54 log units) above what was measured, and the stated range ends above it.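

In this assay the methoxy change gives a 1.1-fold higher number from compound 3 to compound 4 (0.03 log units; within the scatter), and this step does not match the one on the other core: the same change on two cores in this assay, a 3.8-fold higher number (0.58 log units; beyond the scatter) from compound 1 to compound 2 and a 1.1-fold higher number (0.03 log units; within the scatter) from compound 3 to compound 4, 3.6-fold (0.56 log units) apart, beyond the scatter of two such steps. For these two pairs, then, the size of the methoxy step does not carry over from one core to the other, so a step read on one core gave no safe figure for the other. Two pairs in one assay do not show why the steps part, nor how the change would behave on any further core.

As far as these compounds go, it stays open whether an amine or a carboxylic acid on the same aromatic carbon would follow methoxy on either core. From the compounds shown here alone, a longer chain such as ethoxy is equally open.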